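Moving the Fluorine Around the Anilino Ring

A few compounds are considered here, and "the series" means these few. Any claim that something is new, unique, unknown or untested is made for them only; others in the source may bear on it.

Compound 1 `CC1CCn2c(ncc(C(=O)O)c2=O)/C1=N/Nc1ccccc1`: > 320 umol/kg
Compound 2 `CC1CC/C(=N\Nc2ccccc2F)c2ncc(C(=O)O)c(=O)n21`: > 1000 umol/kg

In a functional assay on the whole organism for inhibition, with Rattus norvegicus as the target (a lower number here means that less compound is needed, a higher number that more compound is needed for the effect), compound 1 gives > 320 umol/kg, which is a limit of the assay rather than a number. Compound 2 gives > 1000 umol/kg in this assay, also a limit. Among the compounds with values here, compound 2 therefore stands at the limit of the measurement, matching (the limit of > 1000 umol/kg in this assay, at which 1 of the 2 values shown sits), while the one other value shown is itself a limit (the limit of > 320 umol/kg in this assay, at which 1 of the 2 values shown sits). Within the data shown here, no step between measured compounds exists here.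

Compound 3 `CC1CC/C(=N\Nc2ccc(F)cc2)c2ncc(C(=O)O)c(=O)n21` differs from compound 2 by 4-fluorophenyl in place of 2-fluorophenyl on an amine nitrogen. The expected step from this change is none beyond the usual scatter, so compound 3 is expected to remain at the limit: estimated 1500 umol/kg, range 500 umol/kg to 5000 umol/kg, with an expected step that the limit leaves unreadable from compound 2 to compound 3.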

Compound 3, dose for 50% inhibition: > 1000 umol/kg
Compound 3 gave a limit, no number (the forecaster's own chance of this, stated with the estimate: 85%); the middle value does not contradict the limit.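

Compound 2 and compound 3 both give only a limit, not a number, and no step can be read between them. The compounds shown leave open whether 4-fluorophenyl in place of 2-fluorophenyl changes the dose needed.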